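Aryl urea swap on the aminoethyl thienopyrimidine series

The source may report more compounds than this note shows. Statements on the series, on what has been measured and on what is new or still open speak of the compounds shown alone.

Measured so far in a functional assay on HT-29 cells (Homo sapiens) for cytotoxicity, read by MTT assay, with a stated time of 72 h; on this read-out higher numbers stand for weaker inhibition and lower numbers for stronger inhibition:
compound 1 `CN(C)CCNc1nc(-c2ccc(NC(=O)Nc3ccc(Cl)cc3)cc2)nc2ccsc12`, 95 nM
compound 2 `CCN(CC)CCCNc1nc(-c2ccc(NC(=O)Nc3ccc(Cl)cc3)cc2)nc2ccsc12`, 58 nM
compound 3 `CCN(CC)CCNc1nc(-c2ccc(NC(=O)Nc3ccccc3F)cc2)nc2ccsc12`, 610 nM

Compound 3 stands highest of the three numbers in this assay; compound 1 lies nearer to it and compound 2 furthest, and both gaps lie beyond the scatter. Both of those compounds carry the 4-chlorophenyl urea, whereas compound 3 carries the 2-fluorophenyl urea.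

Compound 4 `CCN(CC)CCNc1nc(-c2ccc(NC(=O)Nc3ccc(Cl)cc3)cc2)nc2ccsc12` is not yet measured. It differs from compound 3 in one place: 4-chlorophenyl in place of 2-fluorophenyl on an amide-type nitrogen. The change brings in the urea aryl group shared by compound 1 and compound 2. Going by the values given here, no measured step isolates this swap. Among the compounds with values here, the only measured step, a 1.6-fold lower number from compound 1 to compound 2 (0.21 log units; within the scatter), concerns the amine end of the chain, not the urea, and is within the scatter; it says little here except that the two 4-chlorophenyl compounds sit close together. Compound 4 keeps the diethylaminoethyl chain of compound 3 and takes the 4-chlorophenyl of compound 1 and compound 2, so the expectation is that its number in this assay falls back toward those of compound 1 and compound 2, a step of a 7.6-fold lower number from compound 3 to compound 4 (0.88 log units; beyond the scatter) expected from compound 3 to compound 4. The estimate for compound 4 is 80 nM, with a range from 30 nM to 250 nM.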

Compound 4, half-maximal inhibitory concentration: 150 nM
Beside the measured number, compound 4's estimate is 1.9-fold (0.27 log units) below it; low and high end bracket the measured number.
By their numbers in this assay, from the lowest: compounds 2, 1 and 4 (each within the scatter of the next, the first and the last beyond it); then compound 3.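

In this assay the urea aryl swap can now be read on its own on the diethylaminoethyl chain: 4-chlorophenyl in place of 2-fluorophenyl on the amide-type nitrogen gives a 4.1-fold lower number from compound 3 to compound 4 (0.61 log units; beyond the scatter), a modest step beyond the scatter, so this position does respond to the aryl group. With the 4-chlorophenyl urea held fixed, the amine end can also be read: diethylamino in place of dimethylamino gives a 1.6-fold higher number from compound 1 to compound 4 (0.20 log units; within the scatter), which stays within the scatter, while diethylamino in place of (diethylamino)methyl gives a 2.6-fold higher number from compound 2 to compound 4 (0.41 log units; beyond the scatter), a modest step beyond it. No measurement at hand offers a reason for any of these steps.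

Only 2-fluorophenyl and 4-chlorophenyl appear on this nitrogen, so the halogen and its place on the ring are changed together, and 4-fluorophenyl, 2-chlorophenyl or plain phenyl would be needed to separate them. Going by these compounds, at the amine end, morpholine, piperidine or a longer chain remain open.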